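The source may report more compounds than this note shows. Statements on the series, on what has been measured and on what is new or still open speak of the compounds shown alone.

In a toxicity assay on THP-1 cells (Homo sapiens) for inhibition (on this read-out lower numbers stand for higher toxicity in this test and higher numbers for lower toxicity in this test), three compounds have been measured so far. Compound 1 `Cc1cccc(C(=O)Nc2ncc(-c3ccccc3)n2C)c1` gives > 50000 nM, which is a limit of the assay and not a number. Compound 2 `COc1ccc(-c2ccnc(NC(=O)c3ccc(F)cc3)c2)cc1` gives > 100000 nM, which is also a limit. Compound 3 `O=C(Nc1ncc(-c2ccccc2)o1)c1ccc(F)cc1` gives an actual number, 17000 nM. Going by these compounds, compound 1 therefore stands as one of two compounds known only by a limit, and its true value remains open.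

Compound 4 `Cn1c(-c2ccccc2)cnc1NC(=O)c1ccc(Br)cc1` keeps the core of compound 1 and changes a single group: 4-bromophenyl in place of 3-methylphenyl on a carbonyl carbon. In words, 4-bromophenyl takes the place of 3-methylphenyl on a carbonyl carbon. Going by the values given here, no two measured compounds differ in only one place, so the data offer no direct measure of such a swap.

In this assay, a small move toward higher toxicity is expected, with the estimated step of an at least 1.2-fold lower number from compound 1 to compound 4 (0.09 log units; that floor lies within the scatter). Among the compounds with values here, this expectation leans on compound 3 at 17000 nM, the only measured number. For compound 4, the expected half-maximal cytotoxic concentration is 40000 nM, with an estimated range of 12000 nM to 100000 nM.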

Compound 4, half-maximal cytotoxic concentration: > 100000 nM
Compound 4: a limit, no number (the forecaster's own chance of this, stated with the estimate: 50%); middle value at least 2.5-fold (0.39 log units) from the limit.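

In this assay compound 4 gives > 100000 nM, which is a limit and not a number. Going by these compounds alone, compound 1 is also known only by a limit, so no step between compound 1 and compound 4 can be read. The compounds shown leave open what 4-bromophenyl in place of 3-methylphenyl on a carbonyl carbon does to the half-maximal cytotoxic concentration.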